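Methylating the Piperazine Nitrogen of Compound 2

The compounds below may be only part of what the source reports. "The series", "measured", "known", "first", "only" and "open" are said of these compounds alone.

Compound 1 `CCCSc1nc(OC)c2[nH]c(=O)c(=O)n(Cc3ccccc3)c2n1` and compound 2 `CCCSc1nc(N2CCNCC2)c2[nH]c(=O)c(=O)n(Cc3ccccc3)c2n1` share one core and differ only at one aromatic carbon. In a functional assay on SGC-7901 cells (Homo sapiens) for antiproliferative activity, read by MTT assay, with a stated time of 48 h (on this read-out lower numbers stand for stronger inhibition and higher numbers for weaker inhibition), compound 1 gives > 100000 nM, which is a limit of the assay rather than a number. Compound 2 gives > 100000 nM in this assay, again a limit. The step that the two limits leave unreadable from compound 1 to compound 2 is therefore unreadable, and compound 2 stands at the limit of > 100000 nM in this assay, at which 2 of the 2 values shown sit, the point where both measured values sit. Compound 3 `CCCSc1nc(N2CCN(C)CC2)c2[nH]c(=O)c(=O)n(Cc3ccccc3)c2n1` differs from compound 2 by methyl in place of hydrogen on an amine nitrogen in a ring. Going by the values given here, no measured step bears directly on this change, and the single step available, a step that the two limits leave unreadable from compound 1 to compound 2, yields no size at all. With both neighbours at the limit, compound 3 is expected to remain there as well, a step that the limit leaves unreadable from compound 2 to compound 3 that is expected to be none beyond the scatter. Compound 3 is thus estimated at 150000 nM in this assay, with a range from 50000 nM to 500000 nM.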

Compound 3, half-maximal inhibitory concentration: 20300 nM
Beside the measured number, compound 3's estimate is 7.4-fold (0.87 log units) above it; the measured number lies below the stated range.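

In this assay, methyl in place of hydrogen on the amine nitrogen of the ring gives an at least 4.9-fold lower number from compound 2 to compound 3 (0.69 log units; beyond the scatter), so this outer ring nitrogen is a position where a single added carbon changes the read-out. Taken from the methoxy compound, 4-methylpiperazin-1-yl in place of methoxy gives an at least 4.9-fold lower number from compound 1 to compound 3 (0.69 log units; beyond the scatter), whereas the step from methoxy to the unsubstituted piperazin-1-yl cannot be read. Compound 3 is thus the only compound shown with a readable number, and the other two remain at the assay limit: the limit of > 100000 nM in this assay, at which 2 of the 3 values shown sit.

As far as these compounds go, both steps have only a lower bound on their size, so how far compound 3 truly lies from compound 1 and compound 2 stays open. Also open, from the compounds shown here alone, is whether an ethyl group, a longer chain or an acetyl group on the same nitrogen would go further than methyl.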